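The source may report more compounds than this note shows. Statements on the series, on what has been measured and on what is new or still open speak of the compounds shown alone.

Compound 1 `CC(C(=O)N1CCN(c2ccccc2)CC1)N1C(=O)CCC1=O` gives 0% in a functional assay on the whole organism (strain Swiss) with Mus musculus as the target, in the maximal electroshock model, with a stated time of 2 h, at a dose of 100 mg/kg by the intraperitoneal route; a higher number here means a stronger effect of the compound at the dose given, a lower number a weaker effect.
Compound 2 `CCC(C(=O)N1CCN(c2cccc(F)c2)CC1)N1C(=O)CCC1=O` gives 0% in this assay.
Compound 3 `CC(C(=O)N1CCN(c2cccc(F)c2)CC1)N1C(=O)CCC1=O` gives 0% in this assay.

Compound 3 thus stands level with compounds 1 and 2 at the digits shown. Compound 4 `CC(C(=O)N1CCN(c2cccc(Cl)c2)CC1)N1C(=O)CCC1=O` differs from it by chloro in place of fluoro on an aromatic carbon. Two measured steps are the nearest relatives: no change at the digits printed from compound 1 to compound 3 (within the scatter), where fluoro replaced hydrogen on the same aromatic ring, and no change at the digits printed from compound 2 to compound 3 (within the scatter), a change on the chain. Among the compounds with values here, neither swaps one halogen for another, so no step speaks directly to this change, and none moved the read-out. On that basis the change is expected to produce a number 5 percentage points higher from compound 3 to compound 4 (within the scatter), with no movement beyond the scatter. Compound 4 is therefore estimated at 5%, within a range from 0% to 25%.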

Compound 4, a percentage reported as activity, at one dose (the size of the read-out at that dose, not a potency): 0%
Compound 4: the middle estimate sits 5 percentage points above what was measured; measured number inside the range.
By their numbers in this assay, from the lowest: compounds 1, 2, 3 and 4 (each within the scatter of the next).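

Chloro in place of fluoro on this aromatic carbon, meta to a large group, gives no change at the digits printed from compound 3 to compound 4 (within the scatter) in this assay, and chloro in place of hydrogen gives no change at the digits printed from compound 1 to compound 4 (within the scatter). So the heavier halogen, like fluoro before it, does not lift the read-out at this position at the dose given. With all four compounds level, this assay does not separate them. Still open, going by these compounds, is whether methoxy or trifluoromethyl at this place, or a longer chain on the shared core, would produce any effect. Nothing available explains the lack of effect of either halogen.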